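The source may hold more compounds than are shown below. What is called first, only, known or untested is meant among the compounds shown, and "the series" means these compounds.

Compound 2 `CC(=O)Oc1ccc(N2C(=O)/C(=C/N3N=C(c4ccc5ccccc5c4)CC3c3ccc(Cl)cc3)SC2=S)cc1` is measured in a functional assay on SK-OV-3 cells (Homo sapiens) for antiproliferative activity, read by MTT assay, with a stated time of 72 h (a lower number here means a stronger inhibitor, a higher number a weaker inhibitor), and gives > 10000 nM, which is a limit of the assay and not a number. Compound 1 `CC(=O)Oc1ccc(N2C(=O)/C(=C/N3N=C(c4ccc5ccccc5c4)CC3c3ccccc3O)SC2=S)cc1` gives > 10000 nM, likewise a limit. Compound 3 `COc1ccc(C2CC(c3ccc4ccccc4c3)=NN2/C=C2\SC(=S)N(c3ccc(OC(C)=O)cc3)C2=O)cc1` gives 1100 nM. For the measured compounds named here, from compound 2 the only readable step is an at least 9.0-fold lower number from compound 2 to compound 3 (0.95 log units; beyond the scatter), while the step that the two limits leave unreadable from compound 1 to compound 2 cannot be sized, so compound 2 stands at the limit of > 10000 nM in this assay, at which 2 of the 3 values shown sit, together with compound 1. Compound 4 `CC(=O)Oc1cccc(N2C(=O)/C(=C/N3N=C(c4ccc5ccccc5c4)CC3c3ccc(Cl)cc3)SC2=S)c1` differs from compound 2 by 3-acetoxyphenyl in place of 4-acetoxyphenyl on an amide-type nitrogen in a ring. Going by the values given here, no measured step touches this amide-type nitrogen, so in this assay no step beyond the scatter is expected. The step expected is a step that the limit leaves unreadable from compound 2 to compound 4. Compound 4 is estimated at 15000 nM, between 5000 nM and 50000 nM, most probably reported again as a limit.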

Compound 4, half-maximal inhibitory concentration: 2390 nM
Compound 4: middle estimate off by 6.3-fold (0.80 log units), on the high side; the whole stated range lies above it.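

3-Acetoxyphenyl in place of 4-acetoxyphenyl on the amide-type nitrogen is the first change at this place, and in this assay it gives an at least 4.1-fold lower number from compound 2 to compound 4 (0.62 log units; beyond the scatter). The move of the acetoxy group alone, with the 4-chlorophenyl group unchanged, is enough to give a readable number. The value of compound 2 is a limit: the limit of > 10000 nM in this assay, at which 2 of the 4 values shown sit.

On these data alone, whether 3-acetoxyphenyl gives a similar step alongside the 4-methoxyphenyl group of compound 3 remains open. Also open, as far as these compounds go, is whether an amine or a carboxylic acid in place of the acetoxy group would retain the activity of compound 4.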